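This account rests on a few compounds, and the source may have more. Where it says the series, first, only, none or still open, it means among the compounds named here.

In an assay on mitochondria from L6 cells (Rattus norvegicus) for activation, with a stated time of 90 min (on this read-out lower numbers stand for an effect already at smaller amounts and higher numbers for an effect only at larger amounts of compound), the measured compounds stand as follows:

compound 1 `Oc1nc2nonc2nc1Nc1ccc(OCC(F)(F)F)cc1`: 42300 nM
compound 2 `Oc1nc2nonc2nc1Nc1ccc(OCC(F)(F)F)c(C(F)(F)F)c1`: 4000 nM
compound 3 `Oc1nc2nonc2nc1Nc1cccc(C(F)(F)F)c1`: 13300 nM

The change from compound 1 to compound 2 is trifluoromethyl in place of hydrogen on an aromatic carbon and produced an 11-fold lower number from compound 1 to compound 2 (1.02 log units; beyond the scatter). From compound 2 to compound 3 the change gave a 3.3-fold higher number from compound 2 to compound 3 (0.52 log units; beyond the scatter). Compound 1 and compound 3 differ in their cores; that difference is not broken down here.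

Compound 4 `Oc1nc2nonc2nc1Nc1cc(C(F)(F)F)cc(C(F)(F)F)c1` is not yet measured. It differs from compound 3 by trifluoromethyl in place of hydrogen on an aromatic carbon. This is the same kind of change as from compound 1 to compound 2, but not the same: there the entering group sat ortho to a 2,2,2-trifluoroethoxy group and meta to a large group, whereas in compound 4 it sits meta to a large group and meta to a trifluoromethyl group. A step of about a 5.3-fold lower number from compound 3 to compound 4 (0.73 log units; beyond the scatter) in this assay is expected, somewhat smaller than the earlier one; this rests on compound 2, whose step an 11-fold lower number from compound 1 to compound 2 (1.02 log units; beyond the scatter) was large, tempered by the changed surroundings. Compound 4 is estimated at 2500 nM, between 800 nM and 8000 nM.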

Compound 4, half-maximal effective concentration: 4500 nM
Compound 4: the middle estimate sits 1.8-fold (0.26 log units) below what was measured, within the range that was stated.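

In this assay the trifluoromethyl change again lowers the number, with a 3.0-fold lower number from compound 3 to compound 4 (0.47 log units; beyond the scatter) in this second pair, so the direction of the step holds across the two cores shown. Its size does not carry over: the same change on two cores in this assay, an 11-fold lower number (1.02 log units; beyond the scatter) from compound 1 to compound 2 and a 3.0-fold lower number (0.47 log units; beyond the scatter) from compound 3 to compound 4, 3.6-fold (0.55 log units) apart, beyond the scatter of two such steps. Two pairs show neither what sets the size of the step nor how it would turn out on a further core, so the step from one core gives only its direction for another.

Open, on these data alone, is how a nitrile, an amine or a carboxylic acid on the aromatic ring would stand against trifluoromethyl. Also open, as far as these compounds go, is how a longer chain in place of 2,2,2-trifluoroethoxy would read in this assay.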